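This account rests on a few compounds, and the source may have more. Where it says the series, first, only, none or still open, it means among the compounds named here.

Compound 1 `COc1ccccc1NC(=O)c1ccccc1Sc1ccc([N+](=O)[O-])cc1`, compound 2 `COc1ccccc1NC(=O)c1cc(NC(C)=O)ccc1Sc1ccc([N+](=O)[O-])cc1` and compound 3 `COc1ccccc1NC(=O)c1cc(C(F)(F)F)ccc1Sc1ccc([N+](=O)[O-])cc1` share one core and differ only in a single substituent. Going by the values given here, in an ADME assay on H9 cells (Homo sapiens) for cytotoxicity, read by MTT assay, with a stated time of 7 days (a higher number here means that more compound is tolerated, a lower number that less compound is tolerated), compound 2 gives 171000 nM, and this is the only number in the set: compound 1 gives "not determined" (no result reported) in this assay, and compound 3 gives "not determined" (no result reported), so compound 2 stands alone and cannot be ranked against them. Compound 4 `COc1ccccc1NC(=O)c1cc(N(C)C)ccc1Sc1ccc([N+](=O)[O-])cc1` is the next step from compound 2 and carries the change (dimethylamino in place of acetamido on an aromatic carbon). Among the compounds with values here, no measured pair gives a step of this kind, so there is no reference for its size. Compound 4 is therefore expected to stay near compound 2, with a step of a 1.3-fold lower number from compound 2 to compound 4 (0.12 log units; within the scatter) that is estimated to lie within the scatter. For compound 4 the estimate in this assay is 130000 nM, in the range 45000 nM to 350000 nM.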

Compound 4, half-maximal cytotoxic concentration: 182000 nM
Compound 4: the middle estimate sits 1.4-fold (0.15 log units) below what was measured; the range from low to high includes it.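

In this assay, going by these compounds alone, the first measured pair of the set shows a 1.1-fold higher number from compound 2 to compound 4 (0.03 log units; within the scatter) and so, at this aromatic carbon para to a (4-nitrophenyl)sulfanyl group, dimethylamino and acetamido cannot be told apart. This holds even though the hydrogen-bond donor and the double bond outside aromatic rings leave with acetamido. Nothing measured here explains this likeness. The compounds shown leave open whether a carboxylic acid, a primary amine or a longer alkyl chain on this carbon would move the number beyond the scatter.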